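The source may hold more compounds than are shown below. What is called first, only, known or untested is meant among the compounds shown, and "the series" means these compounds.

Of the compounds shown here, three built on one shared core have been measured in an assay for binding affinity to dual specificity mitogen-activated protein kinase kinase 4 (Homo sapiens), read by KINOMEscan, tested at 100 nM; a higher number here means a weaker effect of the compound at the concentration tested, a lower number a stronger effect. Compound 1, `CCCS(=O)(=O)Nc1ccc(F)c(C(=O)c2n[nH]c3ncc(-c4ccc(N(C)C)cc4)cc23)c1F`, gives 2.5%. Compound 2, `CCCS(=O)(=O)Nc1ccc(F)c(C(=O)c2n[nH]c3ncc(-c4ccc(S(=O)(=O)NCC)cc4)cc23)c1F`, gives 3%. Compound 3, `CCCS(=O)(=O)Nc1ccc(F)c(C(=O)c2n[nH]c3ncc(-c4ccc(NS(C)(=O)=O)cc4)cc23)c1F`, gives 0.85%, the lowest of the three numbers, although the step of a number 1.7 percentage points lower from compound 1 to compound 3 (within the scatter) and the step of a number 2.2 percentage points lower from compound 2 to compound 3 (within the scatter) both lie within the scatter, so nothing separates the three compounds in this assay. Compound 4, `CCCS(=O)(=O)Nc1ccc(F)c(C(=O)c2n[nH]c3ncc(-c4ccc(S(N)(=O)=O)cc4Cl)cc23)c1F`, has not yet been measured. It differs from compound 3 by 2-chloro-4-sulfamoylphenyl in place of 4-(methanesulfonamido)phenyl on an aromatic carbon. Among the compounds with values here, the steps that bear on this change are the ones that swap the group on the same aromatic carbon: a number 0.5 percentage points higher from compound 1 to compound 2 (within the scatter), a number 1.7 percentage points lower from compound 1 to compound 3 (within the scatter) and a number 2.2 percentage points lower from compound 2 to compound 3 (within the scatter). All three were small and within the scatter, so the step of a number 1.2 percentage points higher from compound 3 to compound 4 (within the scatter) is expected to stay within the scatter as well. Within the data shown here, the chlorine in the entering group has no counterpart among the measured compounds, which widens the range of the estimate. For compound 4 the value expected in this assay is 2%, with a range from 0.3% to 15%.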

Compound 4, a percentage reported as activity, at one concentration (the size of the read-out at that concentration, not a potency): 3.4%
Estimate against measurement, compound 4: 1.4 percentage points below; measured number inside the range.
By their numbers in this assay, from the lowest: compounds 3, 1, 2 and 4 (each within the scatter of the next).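

Within the data shown here, the new steps, a number 2.6 percentage points higher from compound 3 to compound 4 (within the scatter) and a number 0.4 percentage points higher from compound 2 to compound 4 (within the scatter) and a number 0.9 percentage points higher from compound 1 to compound 4 (within the scatter), show that in this assay the result holds even when the entering group carries a chlorine, which none of the earlier compounds has. At this aromatic carbon of the shared core, four different substituted phenyl groups now give numbers that cannot be told apart, so this change reveals no preference among them. No measurement shown explains this tolerance of the chlorine.

Going by these compounds, compound 4 differs in both the chlorine and the sulfonyl-containing group, so the effect of each alone stays unknown, and a plain 4-sulfamoylphenyl group would help separate them. On these data alone, it also remains open whether a carboxylic acid on that phenyl ring, or a bromine or methyl in place of the chlorine, would give a similar number.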